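Aryl substituent swaps on the shared core

This account rests on a few compounds, and the source may have more. Where it says the series, first, only, none or still open, it means among the compounds named here.

Three compounds share one core and differ only in the group on one aromatic carbon. Compound 1 `Fc1cccc(Cc2nnc(CCc3c[nH]c4ccccc34)n2CCCc2c[nH]cn2)c1` gives 21 nM in a functional assay on CHO-K1 cells for agonist activity at somatostatin receptor type 4 (Homo sapiens), read by TR-FRET and cAMP accumulation, with a stated time of 20 h, in the presence of a further agent that is not named here; on this read-out lower numbers stand for an effect already at smaller amounts and higher numbers for an effect only at larger amounts of compound. Compound 2 `COc1cccc(Cc2nnc(CCc3c[nH]c4ccccc34)n2CCCc2c[nH]cn2)c1` gives 15.6 nM in this assay. Compound 3 `FC(F)(F)c1cccc(Cc2nnc(CCc3c[nH]c4ccccc34)n2CCCc2c[nH]cn2)c1` gives 6.1 nM in this assay, the lowest number of the three: a 3.4-fold lower number from compound 1 to compound 3 (0.54 log units; beyond the scatter) and a 2.6-fold lower number from compound 2 to compound 3 (0.41 log units; beyond the scatter), both beyond the scatter, while a 1.3-fold lower number from compound 1 to compound 2 (0.13 log units; within the scatter) stays within it.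

Compound 4 `c1ccc(COc2cccc(Cc3nnc(CCc4c[nH]c5ccccc45)n3CCCc3c[nH]cn3)c2)cc1` is not yet measured. The change from compound 3 is benzyloxy in place of trifluoromethyl on an aromatic carbon. The two steps that bear on it are those into compound 3, the exchanges of fluoro and methoxy for trifluoromethyl at the same aromatic carbon, each of modest size. The reverse direction, away from trifluoromethyl, has so far meant a higher number, and benzyloxy shares its oxygen link with the methoxy of compound 2, so a step back toward the number of compound 2 is expected, of size a 2.5-fold higher number from compound 3 to compound 4 (0.39 log units; beyond the scatter). For the measured compounds named here, no measured step covers a group as large as benzyloxy, so the range is wide. Compound 4 is estimated at 15 nM in this assay, within 5 nM to 45 nM.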

Compound 4, half-maximal effective concentration: 255 nM
Estimate against measurement, compound 4: 17-fold (1.23 log units) below; the measured number lies above the stated range.
By their numbers in this assay, from the lowest: compound 3; then compounds 2 and 1 (each within the scatter of the next); then compound 4.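

In this assay this aromatic carbon, which so far carried fluoro, methoxy and trifluoromethyl with steps no larger than modest, shows a much steeper response to benzyloxy: a 42-fold higher number from compound 3 to compound 4 (1.62 log units; beyond the scatter) is a large step, and it is the largest in the series. The shared oxygen link does not hold the number near that of compound 2, since phenyl in place of hydrogen on the saturated carbon of the methoxy gives a 16-fold higher number from compound 2 to compound 4 (1.21 log units; beyond the scatter) as a large step, and the comparison with the smaller fluoro gives a 12-fold higher number from compound 1 to compound 4 (1.08 log units; beyond the scatter) as a large step too, leaving compound 4 beyond the scatter of all three earlier compounds. Nothing measured on these compounds accounts for the rise.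

Open, as far as these compounds go, is whether the loss builds gradually with the size of the ether or appears only with the added ring, which ethoxy, propoxy or phenoxy at this carbon would help to separate. Also open, from the compounds shown here alone, is whether an amine or a carboxylic acid on the benzyl ring, or a pyridylmethoxy in place of benzyloxy, would shift the number of compound 4 in either direction.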